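Adding a Fourth Methoxy Group to the Stronger Chalcone-Type Core

A few compounds are considered here, and "the series" means these few. Any claim that something is new, unique, unknown or untested is made for them only; others in the source may bear on it.

Of the compounds shown here, three have so far been measured in a functional assay on HeLa cells (Homo sapiens) for inhibition, read by MTT assay, with a stated time of 72 h; a lower number here means a stronger inhibitor, a higher number a weaker inhibitor. Compound 1 `COc1cc(OC)c(C(=O)/C=C/c2ccc(O)cc2)c(OC)c1` gives 40600 nM. Compound 2 `COc1cc(OC)c(C(=O)/C=C/c2ccc(O)c(OC)c2)c(OC)c1` differs from compound 1 by methoxy in place of hydrogen on an aromatic carbon; in this assay compound 2 gives 44900 nM. The step of a 1.1-fold higher number from compound 1 to compound 2 (0.04 log units; within the scatter) lies within the scatter, so the two read as equal. Compound 3 `COc1cc(/C=C/C(=O)c2c(OC)cc(OC)cc2OC)cc(OC)c1` gives 9200 nM, the lowest of the three numbers, and the difference between its core and the core of compound 1 is not broken down here.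

Compound 4 `COc1cc(OC)c(C(=O)/C=C/c2cc(OC)c(OC)c(OC)c2)c(OC)c1` has not yet been measured. It differs from compound 3 by methoxy in place of hydrogen on an aromatic carbon. This is the same kind of change as that from compound 1 to compound 2, but not the same change: there the new group sat ortho to a hydroxy group and meta to a large group, here it sits ortho to two methoxy groups and para to a large group. Because the earlier step of a 1.1-fold higher number from compound 1 to compound 2 (0.04 log units; within the scatter) stayed within the scatter, a comparably small step is expected here, a 1.0-fold lower number from compound 3 to compound 4 (0.01 log units; within the scatter). Compound 4 is therefore estimated at 9000 nM, with a likely range from 3000 nM to 27000 nM.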

Compound 4, half-maximal inhibitory concentration: 9900 nM
Compound 4: middle estimate off by 1.1-fold (0.04 log units), on the low side, and the stated range covers the measured number.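

In this assay the new step, a 1.1-fold higher number from compound 3 to compound 4 (0.03 log units; within the scatter), is as small as the earlier one, and the two steps agree: the same change on two cores in this assay, a 1.1-fold higher number (0.04 log units; within the scatter) from compound 1 to compound 2 and a 1.1-fold higher number (0.03 log units; within the scatter) from compound 3 to compound 4, 1.0-fold (0.01 log units) apart, within the scatter of two such steps. On the two cores shown, then, a methoxy group in place of a hydrogen on an aromatic carbon gives a number that cannot be told apart from that of the parent compound, even though in compound 4 the new group sits ortho to two methoxy groups and para to a large group. Within the data shown here, this rests on only two pairs of compounds, so it does not show that the same would hold on a third core or at another place on the ring, and it says nothing about why the steps are so small.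

The compounds shown leave open what an amine, a carboxylic acid or a longer chain such as ethoxy would do in place of this methoxy group. They also leave open whether the agreement between the two steps would hold in any other assay.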